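Saturating the Side Chain of Compound 2

A few compounds are considered here, and "the series" means these few. Any claim that something is new, unique, unknown or untested is made for them only; others in the source may bear on it.

For the measured compounds named here, in a functional assay on HCT-116 cells (Homo sapiens) for antiproliferative activity, read by sulforhodamine B assay, with a stated time of 72 h (on this read-out lower numbers stand for stronger inhibition and higher numbers for weaker inhibition), compound 1 (`Cn1ncc(Cl)c1-c1cc(C(=O)N[C@@H]2CN[C@H](CCn3cncn3)C[C@H]2c2ccc(Cl)c(Cl)c2)oc1Cl`) gives 560 nM and compound 2 (`C=CC[C@@H]1C[C@@H](c2ccc(Cl)c(Cl)c2)[C@H](NC(=O)c2cc(-c3c(Cl)cnn3C)c(Cl)o2)CN1`) gives 780 nM, so compound 2 stands within the usual scatter of its only measured neighbour. Compound 3 (`CCC[C@@H]1C[C@@H](c2ccc(Cl)c(Cl)c2)[C@H](NC(=O)c2cc(-c3c(Cl)cnn3C)c(Cl)o2)CN1`) alters compound 2 in one place: ethyl in place of vinyl on a saturated chain carbon bound to a saturated ring carbon. Put simply, the allyl of compound 2 becomes propyl in compound 3. Going by the values given here, only one measured step bears on this, at the same place: a 1.4-fold higher number from compound 1 to compound 2 (0.14 log units; within the scatter). There, vinyl replaced (1H-1,2,4-triazol-1-yl)methyl, and the read-out in this assay did not move beyond the scatter. Among the compounds with values here, no measurement yet tests ethyl against vinyl directly. The expected outcome is a 1.0-fold lower number from compound 2 to compound 3 (0.02 log units; within the scatter), which means no change beyond the scatter. For compound 3 the estimated value is 750 nM, with an expected range from 350 nM to 1600 nM.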

Compound 3, half-maximal inhibitory concentration: 1020 nM
Compound 3: the middle estimate sits 1.4-fold (0.13 log units) below what was measured, within the range that was stated.
By their numbers in this assay, from the lowest: compounds 1, 2 and 3 (each within the scatter of the next).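

In this assay, the step from allyl to propyl gives a 1.3-fold higher number from compound 2 to compound 3 (0.12 log units; within the scatter) and so stays within the scatter, which shows that the double bond of the allyl group is not required to keep the read-out in this range. The wider comparison gives a 1.8-fold higher number from compound 1 to compound 3 (0.26 log units; within the scatter) and also stays within the scatter, so at this position a plain propyl chain cannot be told apart from the chain ending in 1H-1,2,4-triazol-1-yl. No measurement shown here explains why these side chains read alike.

On these data alone, all three side chains read within the scatter of one another, so it remains open which kind of group at this position would move the number at all. A chain ending in an amine or a carboxylic acid, or a longer chain such as hexyl, would test that.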